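This account rests on a few compounds, and the source may have more. Where it says the series, first, only, none or still open, it means among the compounds named here.

Compound 2, `CNC(=O)c1cccn(Cc2ccccc2)c1=O`, sits at the top of the two measurements so far in a physicochemical assay for lipophilicity, at pH 7.4 (on this read-out higher numbers stand for higher lipophilicity and lower numbers for lower lipophilicity), where compound 2 gives 3. Among the measured compounds shown here, its only neighbour, compound 1, `CNC(=O)c1cc(C(=O)NCCCC2CNCCO2)cn(Cc2ccccc2)c1=O`, comes in lower: in this assay compound 1 gives 1.4, a gap beyond the usual scatter. Compound 3, `CNC(=O)c1cc(C(=O)NCC(C)C)cn(Cc2ccccc2)c1=O`, is not yet measured. It differs from compound 2 by isobutylcarbamoyl in place of hydrogen on an aromatic carbon on an aromatic carbon of the shared core. For the measured compounds named here, with no measured step of this kind to lean on, a small rise is expected from compound 2 to compound 3, a number 0.30 log units higher from compound 2 to compound 3 (within the scatter), and compound 3 is estimated at 3.3, within a range of 2.7 to 3.9.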

Compound 3, distribution coefficient: 4.3
Beside the measured number, compound 3's estimate is 1.00 log units below it, and the stated range ends below it.
By their numbers in this assay, from the lowest: compound 1; then compound 2; then compound 3.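

In this assay, putting isobutylcarbamoyl on this aromatic carbon, two atoms from the ring nitrogen, gives a number 1.30 log units higher from compound 2 to compound 3 (beyond the scatter) as a large step, so this position is far from silent on this read-out. Isopropyl in place of 2-(morpholin-2-yl)ethyl on the chain gives a number 2.90 log units higher from compound 1 to compound 3 (beyond the scatter) as an even larger printed step, so the far end of this substituent also counts. No evidence on hand accounts for either step. From the compounds shown here alone, whether a carboxylic acid at this aromatic carbon, or a longer chain in place of isopropyl, would move the number the same way stays open.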